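Bromo for 3-cyanophenyl on the shared core: cytotoxicity outlook

A few compounds are considered here, and "the series" means these few. Any claim that something is new, unique, unknown or untested is made for them only; others in the source may bear on it.

The shared core is carried by compound 1 `Cc1cc(-c2ccc(O)cc2)cn2c(CSCCc3ccccc3)cnc12` and compound 2 `Cc1cc(-c2cccc(C#N)c2)cn2c(CSCCc3ccccc3)cnc12`; compound 3 `Cc1cc(Br)cn2c(CSCCc3ccccc3)cnc12` keeps the same core and side chain. In an ADME assay on HEL cells (Homo sapiens) for cytotoxicity, with a stated time of 3 days (on this read-out lower numbers stand for higher toxicity in this test and higher numbers for lower toxicity in this test), compound 1 gives >= 100 ug/mL, which is a limit of the assay and not a number. In this assay compound 2 gives > 100 ug/mL, again a limit rather than a measured number. The step that the two limits leave unreadable from compound 1 to compound 2 is therefore not readable. Compound 2 stands at the limit of > 100 ug/mL in this assay, at which 1 of the 2 values shown sits, while compound 1 stands at the limit of >= 100 ug/mL in this assay, at which 1 of the 2 values shown sits, so compound 2 cannot be ranked against compound 1 on the numbers shown.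

The change to compound 3: bromo in place of 3-cyanophenyl on an aromatic carbon. Among the measured compounds shown here, no measured step bears on this change, as the only step in the set is unreadable, and both measured compounds sit at limits. In this assay compound 3 is expected at 100 ug/mL, with a range from 30 ug/mL to 150 ug/mL. The step implied by this estimate, a number no higher from compound 2 to compound 3 (the limit leaves the size open), is expected to stay within the scatter, and a further limit is the likeliest outcome.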

Compound 3, minimum cytotoxic concentration: >= 2 ug/mL
Compound 3 ended at the assay's limit (the forecaster's own chance of this, stated with the estimate: 65%); the middle value is on the limit's open side.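

In this assay compound 3 gives >= 2 ug/mL, a limit of the assay and not a number. With compound 1 and compound 2 also at limits, the steps from each of them to compound 3 cannot be read. The compounds shown leave open whether exchanging 3-cyanophenyl for bromo on this aromatic carbon changes cytotoxicity at all.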